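Trimming an Alkyl Group in a Lipoxygenase Inhibitor Series

A few compounds are considered here, and "the series" means these few. Any claim that something is new, unique, unknown or untested is made for them only; others in the source may bear on it.

Three measured compounds carry a hydroxylated amide-type nitrogen joined through a sulfur-bearing chain to a core. Compound 3 `CCOc1ccc2nc(SCCNC(=O)N(O)C(C)C)sc2c1` bears an isopropyl on that nitrogen, and in a functional assay for inhibition of Polyunsaturated fatty acid 5-lipoxygenase (Homo sapiens) (on this read-out lower numbers stand for an effect already at smaller amounts and higher numbers for an effect only at larger amounts of compound), compound 3 gives 390 nM. Compound 1 `CCOc1ccc2nc(SCCNC(=O)N(C)O)sc2c1` differs from it in one place, (methyl in place of isopropyl on an amide-type nitrogen), and in this assay compound 1 gives 110 nM; the step is a 3.5-fold lower number from compound 3 to compound 1 (0.55 log units; beyond the scatter). Compound 2 `CC(C)N(O)C(=O)NCCCSc1nc2ccccc2s1` keeps the isopropyl on a different core; how the two cores differ is not broken down here. In this assay compound 2 gives 70 nM, which lies within the usual scatter of the number for compound 1.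

Compound 4 `CN(O)C(=O)NCCCSc1nc2ccccc2s1` has not yet been measured. It differs from compound 2 by methyl in place of isopropyl on an amide-type nitrogen, the same change that led from compound 3 to compound 1, at a place described in identical words. Among the compounds with values here, compound 4 is therefore expected to show a 2.3-fold lower number from compound 2 to compound 4 (0.37 log units; beyond the scatter) in this assay, an expectation resting on the single measured instance, a 3.5-fold lower number from compound 3 to compound 1 (0.55 log units; beyond the scatter), and tempered somewhat since only one pair supports it. The estimate for compound 4 is 30 nM, expected to fall between 10 nM and 100 nM.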

Compound 4, half-maximal effective concentration: 45 nM
The estimate for compound 4 lay 1.5-fold (0.18 log units) below the measured number, within the range that was stated.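

On the core of compound 2, putting methyl in place of isopropyl on the amide-type nitrogen gives a 1.6-fold lower number from compound 2 to compound 4 (0.19 log units; within the scatter) in this assay, so on this core alone the two numbers cannot be told apart. Set beside the step on the other core, the change runs the same way on both, and the sizes of the two steps cannot be separated: the same change on two cores in this assay, a 3.5-fold lower number (0.55 log units; beyond the scatter) from compound 3 to compound 1 and a 1.6-fold lower number (0.19 log units; within the scatter) from compound 2 to compound 4, 2.3-fold (0.36 log units) apart, within the scatter of two such steps

This supports carrying the change from one core to the other without a clear shift in its effect, but it rests on just two pairs, one of which stays within the usual scatter, so it gives neither a reliable size for the step nor a rule for further cores.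

The compounds shown carry only methyl or isopropyl on that nitrogen, which leaves open how an ethyl or a tert-butyl group there would read. Also open, from the compounds shown here alone, is whether the same step would hold on a core bearing an amine or a carboxylic acid.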